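Bromo for methyl: expected step to compound 4

The source may report more compounds than this note shows. Statements on the series, on what has been measured and on what is new or still open speak of the compounds shown alone.

Within the data shown here, the series so far holds compound 1 `Cc1ccc(-c2nn(-c3ccccc3)cc2-c2nc3ccccc3n2S(=O)(=O)c2ccc(C)cc2)cc1`, compound 2 `Cc1ccc(-c2nn(-c3ccccc3)cc2-c2nc3ccccc3n2S(=O)(=O)c2ccc(F)cc2)cc1` and compound 3 `Cc1ccc(-c2nn(-c3ccccc3)cc2-c2nc3ccccc3n2S(=O)(=O)c2ccc(Cl)cc2)cc1`. In an ADME assay on HEK-293T cells (Homo sapiens) for cytotoxicity, read by MTT assay, with a stated time of 24 h (on this read-out lower numbers stand for higher toxicity in this test and higher numbers for lower toxicity in this test), compound 1 gives 79300 nM, compound 2 gives 128000 nM and compound 3 gives 167000 nM. Compound 1 thus sits at the low end of the three numbers, although only its gap to compound 3 lies beyond the scatter.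

Compound 4 `Cc1ccc(-c2nn(-c3ccccc3)cc2-c2nc3ccccc3n2S(=O)(=O)c2ccc(Br)cc2)cc1` keeps the core of compound 1 and carries bromo in place of methyl on an aromatic carbon, para to a large group, so that 4-methylphenyl becomes 4-bromophenyl: bromo in place of methyl on an aromatic carbon.

Two measured steps replace the same methyl. With fluoro the result is a 1.6-fold higher number from compound 1 to compound 2 (0.21 log units; within the scatter), and with chloro it is a 2.1-fold higher number from compound 1 to compound 3 (0.32 log units; beyond the scatter), a modest change. The swap of fluoro for chloro gives a 1.3-fold higher number from compound 2 to compound 3 (0.12 log units; within the scatter), so the two halogen compounds are not separated. Among the measured compounds shown here, no bromo compound has been measured, and the expectation rests on these steps alone. A modest step towards a higher number in this assay is expected, of about the size of the chloro step. The expected step is a 1.9-fold higher number from compound 1 to compound 4 (0.28 log units; within the scatter). The estimated value for compound 4 is 150000 nM, with an expected range of 85000 nM to 270000 nM.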

Compound 4, half-maximal cytotoxic concentration: 159000 nM
Beside the measured number, compound 4's estimate is 1.1-fold (0.03 log units) below it, within the range that was stated.
By their numbers in this assay, from the lowest: compounds 1, 2, 4 and 3 (each within the scatter of the next, the first and the last beyond it).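

In this assay, bromo in place of methyl on this aromatic carbon gives a 2.0-fold higher number from compound 1 to compound 4 (0.30 log units; within the scatter) as its step, so this swap, taken alone, does not clear the usual spread of repeats, whereas the chloro swap from the same methyl compound does so only modestly. The new compound also does not separate from the other two halogen compounds, with a 1.1-fold lower number from compound 3 to compound 4 (0.02 log units; within the scatter) and a 1.2-fold higher number from compound 2 to compound 4 (0.09 log units; within the scatter) as its steps, so fluoro, chloro and bromo at this position, para to a large group, form one unresolved set in which the identity of the halogen has no readable consequence for this read-out. Nothing at hand offers a reason for this lack of separation among the halogens, or for the small distance from the methyl compound.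

Open, on these data alone, is what a group of a different kind in this place, such as an amine, a carboxylic acid or a longer alkyl chain, would do to the number relative to the methyl and halogen compounds. Also open, as far as these compounds go, is whether the same flat halogen set would appear if the shared core were changed elsewhere.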